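The source may report more compounds than this note shows. Statements on the series, on what has been measured and on what is new or still open speak of the compounds shown alone.

Working notes on the series. The shared core is carried by compound 1 `O=C(/C=C/c1ccc(F)cc1)c1cccc(NC(=O)c2cc(-c3ccncc3)n[nH]2)c1` and by compound 2 `O=C(/C=C/c1ccco1)c1cccc(NC(=O)c2cc(-c3ccncc3)n[nH]2)c1`. In a functional assay, read by spectrophotometry, tested at 100 uM (on this read-out higher numbers stand for weaker inhibition and lower numbers for stronger inhibition), compound 1 gives 58700 nM, and in this assay compound 2 gives 72300 nM. Of the two numbers in hand, that of compound 1 is the lower, but the step of a 1.2-fold higher number from compound 1 to compound 2 (0.09 log units; within the scatter) places the two within the scatter of each other, so no order between them can be read.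

The next compound is compound 3 `O=C(/C=C/c1ccc(Cl)cc1Cl)c1cccc(NC(=O)c2cc(-c3ccncc3)n[nH]2)c1`. Relative to compound 1 the change is 2,4-dichlorophenyl in place of 4-fluorophenyl on a double-bonded chain carbon bound to a double-bonded chain carbon. Among the compounds with values here, the only measured step that touches the same place, a 1.2-fold higher number from compound 1 to compound 2 (0.09 log units; within the scatter), is within the scatter; it concerns a different group, and no measured pair speaks to 2,4-dichlorophenyl itself. On this basis the expected step of a 1.3-fold lower number from compound 1 to compound 3 (0.12 log units; within the scatter) is small, with no direction beyond the scatter being predicted. For compound 3 the estimate in this assay is 45000 nM, with a range from 15000 nM to 140000 nM.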

Compound 3, half-maximal inhibitory concentration: 80900 nM
Beside the measured number, compound 3's estimate is 1.8-fold (0.25 log units) below it; measured number inside the range.
By their numbers in this assay, from the lowest: compounds 1, 2 and 3 (each within the scatter of the next).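

In this assay, the place on a double-bonded chain carbon bound to a double-bonded chain carbon now holds three groups: 4-fluorophenyl, furan-2-yl and 2,4-dichlorophenyl. Within the data shown here, the two new steps, a 1.4-fold higher number from compound 1 to compound 3 (0.14 log units; within the scatter) and a 1.1-fold higher number from compound 2 to compound 3 (0.05 log units; within the scatter), both stay within the scatter, so the first direct reading on 2,4-dichlorophenyl gives no order among the three compounds, and the series shows no measurable response at this place so far. Exchanging the one fluorine of 4-fluorophenyl for the two chlorine of 2,4-dichlorophenyl on the six-membered aromatic ring of carbon only therefore gives no readable difference, and nothing in hand bears on why these numbers sit so close together.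

As far as these compounds go, whether an unsubstituted phenyl, an amine, a carboxylic acid or a longer chain at this same place would give a step beyond the scatter remains open. Also open, from the compounds shown here alone, is how far the number depends on the rest of the shared core, as compounds 1, 2 and 3 differ from one another in this one place only.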